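Replacing the oxolane amide with a cyclothiomorpholine amide

This account rests on a few compounds, and the source may have more. Where it says the series, first, only, none or still open, it means among the compounds named here.

Compound 3 `CCN(CC)S(=O)(=O)c1ccc(S(=O)(=O)N2CCC[C@@H](C(=O)N[C@@H]3CCOC3)C2)cc1` carries a (oxolan-3-yl)amino group on its carbonyl carbon. In a functional assay on BXPC-3 cells (Homo sapiens) for inhibition, read by MTT assay, with a stated time of 7 days (on this read-out lower numbers stand for stronger inhibition and higher numbers for weaker inhibition), compound 3 gives 2270 nM, the second highest of the three numbers. Compound 1 `CCN(CC)S(=O)(=O)c1ccc(S(=O)(=O)N2CCC[C@@H](C(=O)N3CCC(OC)CC3)C2)cc1` gives 1420 nM, and the step of a 1.6-fold higher number from compound 1 to compound 3 (0.20 log units; within the scatter) lies within the scatter. Compound 2 `CCN(CC)S(=O)(=O)c1ccc(S(=O)(=O)N2CCC[C@@H](C(=O)N[C@H]3CCOC3)C2)cc1` gives 5270 nM, and the step of a 2.3-fold lower number from compound 2 to compound 3 (0.37 log units; beyond the scatter) is modest, because of the fact that compounds 2 and 3 differ only in the configuration as drawn. Compound 4 `CCN(CC)S(=O)(=O)c1ccc(S(=O)(=O)N2CCC[C@@H](C(=O)N3CCS(=O)(=O)CC3)C2)cc1` differs from compound 3 by 1,1-dioxothiomorpholin-4-yl in place of (oxolan-3-yl)amino on a carbonyl carbon. Compound 4 thus returns to a cyclic tertiary amide like compound 1, whose step a 1.6-fold higher number from compound 1 to compound 3 (0.20 log units; within the scatter) was small, so only a small change is expected, the expected step being a 1.1-fold lower number from compound 3 to compound 4 (0.05 log units; within the scatter). For compound 4 the estimate in this assay is 2000 nM, with a range from 900 nM to 4500 nM.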

Compound 4, half-maximal inhibitory concentration: 4430 nM
Compound 4: middle estimate off by 2.2-fold (0.35 log units), on the low side; the range from low to high includes it.
By their numbers in this assay, from the lowest: compounds 1, 3, 4 and 2 (each within the scatter of the next, the first and the last beyond it).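

In this assay, the 1,1-dioxothiomorpholin-4-yl amide cannot be told apart from either oxolane amide, with a 2.0-fold higher number from compound 3 to compound 4 (0.29 log units; within the scatter) and a 1.2-fold lower number from compound 2 to compound 4 (0.08 log units; within the scatter), although those two oxolane amides do separate from each other, and what distinguishes them is this: the fact that compounds 2 and 3 differ only in the configuration as drawn. Against the other cyclic tertiary amide, a 3.1-fold higher number from compound 1 to compound 4 (0.49 log units; beyond the scatter), so sharing a cyclic tertiary amide does not by itself give matching numbers.

On these data alone, whether a morpholin-4-yl or a plain thiomorpholin-4-yl group on this carbonyl carbon would fall nearer the 4-methoxypiperidin-1-yl or the 1,1-dioxothiomorpholin-4-yl amide stays open. The cause of these steps also stays open.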